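Methyl pattern on the benzohydrazide aryl ring

The source may report more compounds than this note shows. Statements on the series, on what has been measured and on what is new or still open speak of the compounds shown alone.

Within the data shown here, compound 3 `Cc1ccc(C(=O)NN(C(=O)c2ccccc2Cl)C(C)(C)C)cc1` gives 18.6 nM in an assay on cells for agonist activity at ecdysone receptor (Bombyx mori), read by a luciferase reporter, with a stated time of 24 h (on this read-out higher numbers stand for an effect only at larger amounts of compound and lower numbers for an effect already at smaller amounts), and stands lowest of the three numbers measured so far. Compound 2 `CC(C)(C)N(NC(=O)c1ccc(F)cc1)C(=O)c1ccccc1Cl` gives 389 nM in this assay and compound 1 `CC(C)(C)N(NC(=O)c1cccc(C#N)c1)C(=O)c1ccccc1Cl` gives 955 nM. The steps of a 2.5-fold lower number from compound 1 to compound 2 (0.39 log units; beyond the scatter), a 51-fold lower number from compound 1 to compound 3 (1.71 log units; beyond the scatter) and a 21-fold lower number from compound 2 to compound 3 (1.32 log units; beyond the scatter) all sit on the aryl group attached to the carbonyl carbon whose other neighbour is the amide-type nitrogen, and they show that this position decides the number strongly.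

Compound 4 `Cc1ccc(C)c(C(=O)NN(C(=O)c2ccccc2Cl)C(C)(C)C)c1` carries the change (2,5-dimethylphenyl in place of 4-methylphenyl on a carbonyl carbon). Among the measured compounds shown here, no measured step exchanges 4-methylphenyl for 2,5-dimethylphenyl, so none bears directly on it; the measured steps only show that the identity of this aryl group moves the number by large amounts, and that 4-methylphenyl is the best of the three variants seen. Since compound 4 keeps a methyl-bearing ring but not the 4-methylphenyl of compound 3, a step to higher numbers in this assay is expected, of uncertain size, estimated as a 6.5-fold higher number from compound 3 to compound 4 (0.81 log units; beyond the scatter). For compound 4 the expected number in this assay is 120 nM, with a range from 25 nM to 600 nM.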

Compound 4, half-maximal effective concentration: 1620 nM
Beside the measured number, compound 4's estimate is 14-fold (1.13 log units) below it; measured number above the stated range.
By their numbers in this assay, from the lowest: compound 3; then compound 2; then compounds 1 and 4 (each within the scatter of the next).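

The step to 2,5-dimethylphenyl on the carbonyl carbon, seen as an 87-fold higher number from compound 3 to compound 4 (1.94 log units; beyond the scatter) in this assay, shows that a methyl-bearing aryl ring does not by itself keep the low number of compound 3. Compound 4 also compares poorly with the 4-fluorophenyl variant, with a 4.2-fold higher number from compound 2 to compound 4 (0.62 log units; beyond the scatter) and so beyond the scatter, while a 1.7-fold higher number from compound 1 to compound 4 (0.23 log units; within the scatter) lies within the scatter, so 2,5-dimethylphenyl and 3-cyanophenyl cannot be told apart at this place. Among the four aryl groups, the low number therefore belongs to 4-methylphenyl alone and not to methyl substitution in general, with compound 4 as the direct counterexample.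

Nothing measured here speaks to the reason for these steps. Still open, going by these compounds, are how the number responds to ethyl or methoxy in place of the methyl of 4-methylphenyl, and which of the two methyl groups of 2,5-dimethylphenyl accounts for the higher number of compound 4.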